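This account rests on a few compounds, and the source may have more. Where it says the series, first, only, none or still open, it means among the compounds named here.

In a functional assay on RAW264.7 cells (Mus musculus) for inhibition (a lower number here means a stronger inhibitor, a higher number a weaker inhibitor), compound 1 `C=C[C@H]1[C@H](O[C@@H]2O[C@H](COC(C)=O)[C@@H](OC(C)=O)[C@H](O)[C@H]2OC(=O)c2cccc(O)c2O)OC=C2C(=O)OCC[C@H]21` gives 690 nM. Compound 2 `C=C[C@H]1[C@H](O[C@@H]2O[C@H](COC(=O)c3cccc(O)c3O[C@@H]3O[C@H](CO)[C@@H](O)[C@H](O)[C@H]3O)[C@@H](O)[C@H](O)[C@H]2O)OC=C2C(=O)OCC[C@H]21` is a different matter: in this assay compound 2 returns only a limit, > 200000 nM, so no number is known for it. That limit is the limit of > 200000 nM in this assay, at which 1 of the 2 values shown sits. On the numbers shown, compound 2 therefore stands at the weak end, out of reach of the measurement, while compound 1 has a measured value.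

Compound 3 `C=C[C@H]1[C@H](O[C@@H]2O[C@H](COC(=O)c3cccc(O)c3O[C@@H]3O[C@H](CO)[C@@H](O)[C@H](O)[C@H]3O)[C@@H](O)[C@H](O)[C@H]2OC(=O)c2cccc(O)c2O)OC=C2C(=O)OCC[C@H]21` has not yet been tested in this assay. It differs from compound 2 by (2,3-dihydroxyphenyl)carbonyl in place of hydrogen on an oxygen on a saturated carbon. Compound 2 carries its aromatic acyl group only through a glycosylated ring, whereas compound 1 carries a free (2,3-dihydroxyphenyl)carbonyl on the sugar and sits at a measurable value; compound 3 combines both features. With a limit at one end, the size of the step cannot be fixed from the data, but one expects a move toward stronger inhibition, an at least 10-fold lower number from compound 2 to compound 3 (1.00 log units; beyond the scatter). Compound 3 is estimated at 20000 nM in this assay, with a range from 2000 nM to 200000 nM.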

Compound 3, half-maximal inhibitory concentration: > 200000 nM
Compound 3 ended at the assay's limit; the forecaster's own chance of this, stated with the estimate: 35%; at least 10-fold (1.00 log units) between middle value and limit.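

In this assay compound 3 returns > 200000 nM as a limit and not a number. Among the compounds shown here, compound 2 also stands at a limit, so no step from compound 2 to compound 3 can be read: the limit of > 200000 nM in this assay, at which 2 of the 3 values shown sit. The compounds shown leave open whether (2,3-dihydroxyphenyl)carbonyl in place of hydrogen on this oxygen changes inhibition at all.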